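This account rests on a few compounds, and the source may have more. Where it says the series, first, only, none or still open, it means among the compounds named here.

Compound 1 `COc1ccc(SCc2ccc(/C=C/C(=O)Nc3ccccc3N)cc2)cc1OC` is the weakest of the three compounds measured: in a functional assay on HeLa cells (Homo sapiens) for inhibition, read by CCK-8 assay, with a stated time of 72 h, tested at 8 uM (on this read-out higher numbers stand for more inhibition of growth at the one concentration tested and lower numbers for less inhibition of growth), compound 1 gives 21.9%. Compound 3 `Nc1ccccc1NC(=O)c1ccc(CSc2cccc(F)c2)cc1` gives 78.4% and compound 2 `Cc1ccc(SCc2ccc(C(=O)Nc3ccccc3N)cc2)cc1` gives 79.2%; the gap from compound 1 to each of these two lies beyond the scatter. Compound 4 `CC(C)(C)c1ccc(SCc2ccc(/C=C/C(=O)Nc3ccccc3N)cc2)cc1` differs from compound 1 only at the sulfur (4-(tert-butyl)phenyl in place of 3,4-dimethoxyphenyl on a sulfur). Within the data shown here, the one measured step that bears on this kind of change is the swap of the aryl group on the sulfur between compound 2 and compound 3, which gave a number 0.8 percentage points lower from compound 2 to compound 3 (within the scatter). On that basis she expects the step of a number 3.1 percentage points higher from compound 1 to compound 4 (within the scatter) to stay within the scatter, with no clear direction. Compound 4 is therefore estimated at 25%, in a range from 8% to 45%.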

Compound 4, percent growth inhibition at one concentration: 9.8%
For compound 4 the middle estimate is 15.2 percentage points above the measured one, and the stated range covers the measured number.
By their numbers in this assay, from the lowest: compound 4; then compound 1; then compounds 3 and 2 (each within the scatter of the next).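

In this assay, changing the aryl group on a sulfur can clearly move the number: 4-(tert-butyl)phenyl in place of 3,4-dimethoxyphenyl gives a number 12.1 percentage points lower from compound 1 to compound 4 (beyond the scatter). The earlier swap, a number 0.8 percentage points lower from compound 2 to compound 3 (within the scatter), showed no such shift, but it involved different groups on a different core, so the two steps give no general rule for this position. Nothing available here accounts for the lower number. As far as these compounds go, it remains open how an amine or a carboxylic acid on the aryl ring, or a longer chain on the sulfur, would perform. From the compounds shown here alone, whether 4-(tert-butyl)phenyl would have the same effect on the core of compound 2 also remains open.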